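Benzyl Ether Analogue of a Weak Deacetylase Binder

A few compounds are considered here, and "the series" means these few. Any claim that something is new, unique, unknown or untested is made for them only; others in the source may bear on it.

Compound 1 `O=C(O)CCc1nc2ccccc2nc1OCc1cccs1`: "not active" (no number reported)
Compound 2 `Cn1ccnc1COc1nc2ccccc2nc1CCC(=O)O`: 140000 nM

In an assay for displacement of a labelled ligand from protein deacetylase HDAC6 (Homo sapiens), read by fluorescence polarization, with a stated time of 10 min (a higher number here means a weaker inhibitor, a lower number a stronger inhibitor), compound 1 gives "not active" (no number reported). Among the measured compounds shown here, compound 2 gives 140000 nM in this assay, the only number in the set, so it stands alone as the sole measured point. Compound 3 `O=C(O)CCc1nc2ccccc2nc1OCc1ccccc1` differs from it by phenyl in place of 1-methyl-1H-imidazol-2-yl on a saturated chain carbon bound to an oxygen on an aromatic ring. For the measured compounds named here, no step between two measured compounds is known, so the size of this change cannot be read from the data. A step of no more than the usual scatter, leaning toward weaker binding, is expected for a 1.4-fold higher number from compound 2 to compound 3 (0.15 log units; within the scatter). Compound 3 is expected to give 200000 nM, between 60000 nM and 700000 nM.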

Compound 3, half-maximal inhibitory concentration: "not active" (no number reported)
For compound 3 the study gives words and no number, and the estimate cannot be compared.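

Among the compounds shown here, compound 3, like compound 1, is reported in this assay only in words, so no step from compound 2 to compound 3 can be read. The compounds shown leave open how far benzyl and (1-methyl-1H-imidazol-2-yl)methyl differ in binding. No evidence bears on this result.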